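The source may report more compounds than this note shows. Statements on the series, on what has been measured and on what is new or still open speak of the compounds shown alone.

Measured so far:
Compound 1, `Cc1ccnc(NC(c2ccc(F)cc2)c2ccc3cccnc3c2O)c1`: 140 nM
Compound 2, `Cc1ccnc(NC(c2ccccc2)c2ccc3cccnc3c2O)c1`: < 200 nM (a limit of the assay, not a number)
Compound 3, `COc1ccccc1NC(c1ccccc1)c1ccc2cccnc2c1O`: 390 nM

All three compounds share one core and differ only in the group on the amine nitrogen or in a substituent on the pendant phenyl ring. In an assay for inhibition of protein disulfide-isomerase (Homo sapiens), with a stated time of 1 h (on this read-out lower numbers stand for stronger inhibition and higher numbers for weaker inhibition), compound 1 gives 140 nM. For compound 2 the assay reports only a limit, < 200 nM, and no number. Compound 3 gives 390 nM. The step that the limit leaves unreadable from compound 1 to compound 2 cannot be sized, because one end of it is the limit (the limit of < 200 nM in this assay, at which 1 of the 3 values shown sits). The step of an at least 1.9-fold higher number from compound 2 to compound 3 (0.29 log units; that floor lies within the scatter) is known only as a floor. Compound 2 therefore stands at the limit; where it lies among the numbers cannot be fixed more closely.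

Compound 4, `Cc1ccnc(NC(c2ccc(OCc3ccccc3)cc2)c2ccc3cccnc3c2O)c1`, differs from compound 2 by benzyloxy in place of hydrogen on an aromatic carbon. For the measured compounds named here, the only measured step touching that ring is the unreadable one from compound 1 to compound 2, so no direction can be read for the new group. The step that the limit leaves unreadable from compound 2 to compound 4 is expected to stay within the scatter. Compound 4 is estimated at 180 nM, with a range from 50 nM to 700 nM.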

Compound 4, half-maximal inhibitory concentration: 620 nM
Estimate against measurement, compound 4: 3.4-fold (0.54 log units) below, within the range that was stated.
By their numbers in this assay, from the lowest: compound 1; then compounds 3 and 4 (each within the scatter of the next).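

For the compounds shown here, this ring position, para to a large group on the pendant phenyl ring, now shows a readable change for the first time: in this assay, benzyloxy in place of hydrogen gives an at least 3.1-fold higher number from compound 2 to compound 4 (0.49 log units; beyond the scatter) and benzyloxy in place of fluoro gives a 4.4-fold higher number from compound 1 to compound 4 (0.65 log units; beyond the scatter) at the same place. The step between hydrogen and fluoro cannot be read, but these two steps show that inhibition at this position depends on the group it carries, and that benzyloxy, with its 8 heavy atoms and added aromatic ring, goes with weaker inhibition than fluoro. The step from hydrogen is known only as a floor because compound 2 has a limit of the assay and no number: the limit of < 200 nM in this assay, at which 1 of the 4 values shown sits.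

With a single large group at this position, the compounds shown cannot separate the effect of size from that of the added aromatic ring, and they leave open how a smaller group such as a hydroxyl, an amine or a carboxylic acid would fare there. They also leave open whether benzyloxy would give a similar step with 2-methoxyphenyl on the amine nitrogen in place of 4-methylpyridin-2-yl.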